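Fluoro to nitro: a step no measurement covers yet

The compounds below may be only part of what the source reports. "The series", "measured", "known", "first", "only" and "open" are said of these compounds alone.

In a functional assay on MIA PaCa-2 cells (Homo sapiens) for antiproliferative activity, read by sulforhodamine B assay, with a stated time of 48 h (a lower number here means a stronger inhibitor, a higher number a weaker inhibitor), compound 1 `COc1ccc2nc(-c3ccc(N/C=C\C(=O)c4ccc(OC)c(F)c4)c(C)c3)sc2c1` gives 2300 nM. Within the data shown here, only one neighbour has been measured so far, and compound 2 `COc1ccc2nc(-c3ccc(N/C=C\C(=O)c4ccc(OC)c(F)c4)cc3)sc2c1` gives 1300 nM. These two numbers lie within the usual scatter of each other, so neither compound can be ranked over the other.

Compound 3 `COc1ccc2nc(-c3ccc(N/C=C\C(=O)c4ccc(OC)c([N+](=O)[O-])c4)c(C)c3)sc2c1` keeps the core of compound 1 and alters one group: nitro in place of fluoro on an aromatic carbon. This is nitro in place of fluoro on an aromatic carbon, ortho to a methoxy group, so 3-fluoro-4-methoxyphenyl becomes 4-methoxy-3-nitrophenyl.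

Among the measured compounds shown here, the one measured step is a 1.8-fold lower number from compound 1 to compound 2 (0.25 log units; within the scatter). It is hydrogen in place of methyl on an aromatic carbon, a different change at a different place, and it stays within the scatter. It therefore gives only a weak guide. For the measured compounds named here, no measured compound carries a nitro group, so the data offer no direction for this swap, and no step beyond the scatter is expected in this assay.

For compound 3 the estimated value is 2500 nM, with an expected range of 800 nM to 7500 nM. The expected step is a 1.1-fold higher number from compound 1 to compound 3 (0.04 log units; within the scatter).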

Compound 3, half-maximal inhibitory concentration: 23600 nM
Compound 3: the middle estimate sits 9.4-fold (0.97 log units) below what was measured; measured number above the stated range.
By their numbers in this assay, from the lowest: compounds 2 and 1 (each within the scatter of the next); then compound 3.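

This result shows that the place ortho to a methoxy group is sensitive to what it carries. In this assay, among these compounds, nitro in place of fluoro gives a 10-fold higher number from compound 1 to compound 3 (1.01 log units; beyond the scatter), whereas the only earlier step, the loss of a methyl group elsewhere in the molecule, gave a 1.8-fold lower number from compound 1 to compound 2 (0.25 log units; within the scatter) and so revealed nothing firm. Among the compounds shown here, of the changes seen so far, this is the first that separates two compounds clearly, and it moves toward a weaker inhibitor, so fluoro is the better of the two groups compared at this place. Nothing shown here bears on the reason for this loss.

On these data alone, it remains open whether the loss belongs to nitro in particular or would follow from other groups at this place, such as an amine, a nitrile or a plain hydrogen, which would show how much this position tolerates. As far as these compounds go, it is also open whether nitro in place of fluoro would have the same effect on compound 2, which lacks the methyl group of compound 1.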